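From 4-methylbenzyl to 4-fluorobenzyl in a small series

A few compounds are considered here, and "the series" means these few. Any claim that something is new, unique, unknown or untested is made for them only; others in the source may bear on it.

Four compounds share one core, and three have been through testing. In a functional assay (Platelet, plasma) for inhibition, with Homo sapiens as the target (a higher number here means a weaker inhibitor, a lower number a stronger inhibitor), compound 1 (`N#Cc1cc2c(nc1N1CCC(C(=O)NS(=O)(=O)Cc3ccccc3F)CC1)COC2=O`) gives 23700 nM and compound 3 (`Cc1ccc(CS(=O)(=O)NC(=O)C2CCN(c3nc4c(cc3C#N)C(=O)OC4)CC2)cc1`) gives 4280 nM as the lower of the two numbers available. Compound 2 (`N#Cc1cc2c(nc1N1CCC(C(=O)NS(=O)(=O)C(F)(F)c3ccccc3)CC1)COC2=O`) stands at "not determined" (no result reported) and offers no comparison. Compound 4 (`N#Cc1cc2c(nc1N1CCC(C(=O)NS(=O)(=O)Cc3ccc(F)cc3)CC1)COC2=O`) has yet to be measured. Its difference from compound 3 is counted as fluoro in place of methyl on an aromatic carbon and reads, in words, fluoro in place of methyl on an aromatic carbon, para to a large group.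

Among the compounds with values here, the one measured step that bears on this is a 5.5-fold lower number from compound 1 to compound 3 (0.74 log units; beyond the scatter) and it lies beyond the scatter. That step also removes a fluoro group and brings in a methyl group, but the fluoro stands elsewhere on the ring, so it guides the direction more than the size. No direct swap at one place has been measured. A smaller move toward a higher number is therefore expected, and the estimated change is a 1.8-fold higher number from compound 3 to compound 4 (0.24 log units; within the scatter) as a cautious reading. For compound 4 the estimate is 7500 nM and the expected range runs from 2500 nM to 22000 nM for this compound.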

Compound 4, half-maximal inhibitory concentration: 3500 nM
Compound 4: middle estimate off by 2.1-fold (0.33 log units), on the high side; the range from low to high includes it.
By their numbers in this assay, from the lowest: compounds 4 and 3 (each within the scatter of the next); then compound 1.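

In this assay, fluoro in place of methyl on an aromatic carbon, para to a large group, amounts to a 1.2-fold lower number from compound 3 to compound 4 (0.09 log units; within the scatter), so at this place the two groups cannot be told apart. Keeping the fluoro and changing only 2-fluorophenyl to 4-fluorophenyl gives a 6.8-fold lower number from compound 1 to compound 4 (0.83 log units; beyond the scatter), a clear shift for a group that stays the same and only sits elsewhere on the ring. The earlier step between compound 1 and compound 3 changed the group and its place together; with compound 4 these two changes can be read apart, and among these three compounds the shift goes with the place on the ring and not with methyl versus fluoro.

Nothing shown here accounts for this difference between the two places on the ring. Compound 2 has no number, so its steps cannot be read, and the compounds shown do not tell whether an amine, a carboxylic acid or a longer chain in place of the methyl of the 4-methylbenzyl would stay level with methyl and fluoro.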